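Compound 4: Dropping the Methyl from the Shared Core

A few compounds are considered here, and "the series" means these few. Any claim that something is new, unique, unknown or untested is made for them only; others in the source may bear on it.

In a functional assay on A549 cells (Homo sapiens) for inhibition, read by sulforhodamine B assay, with a stated time of 48 h (a lower number here means a stronger inhibitor, a higher number a weaker inhibitor), compound 1 `CCO[C@H]1C[C@@H](c2coc3ccc(Br)cc3c2=O)N(c2ccccc2)O1` gives 21500 nM.
Compound 2 `O=c1c([C@@H]2C[C@H](c3ccccc3)ON2c2ccccc2)coc2ccc(F)cc12` gives 51500 nM.
Compound 3 `Cc1ccc2occ([C@@H]3C[C@H](c4ccccc4)ON3c3ccccc3)c(=O)c2c1` gives 49000 nM.

Compound 3 holds the second highest of the three numbers; compound 2 sits nearest, within the scatter of it, while compound 1 lies furthest, beyond the scatter. Compound 4 `O=c1c([C@@H]2C[C@H](c3ccccc3)ON2c2ccccc2)coc2ccccc12` differs from compound 3 by hydrogen in place of methyl on an aromatic carbon. For the measured compounds named here, only one measured step touches this position on the core: a 1.1-fold lower number from compound 2 to compound 3 (0.02 log units; within the scatter), a swap of one substituent for another that left the number essentially unmoved. On that basis a step of a 1.0-fold lower number from compound 3 to compound 4 (0.01 log units; within the scatter) is expected, none beyond the scatter. Compound 4 is therefore estimated at 48000 nM, in a range from 22000 nM to 105000 nM.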

Compound 4, half-maximal inhibitory concentration: > 60000 nM
Compound 4: no number, only a limit (the forecaster's own chance of this, stated with the estimate: 10%); middle value at least 1.2-fold (0.09 log units) from the limit.
By their numbers in this assay, from the lowest: compound 1; then compounds 3 and 2 (each within the scatter of the next). At a limit, above all of these: compound 4.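

In this assay compound 4 gives > 60000 nM, a limit of the assay and not a number. Leaving hydrogen on this aromatic carbon, rather than swapping one substituent for another, gives an at least 1.2-fold higher number from compound 3 to compound 4 (0.08 log units; that floor lies within the scatter) and an at least 1.1-fold higher number from compound 2 to compound 4 (0.06 log units; that floor lies within the scatter). Hydrogen here is therefore not shown to differ from methyl or fluoro, but compound 4 is the only compound shown that reaches the limit: the limit of > 60000 nM in this assay, at which 1 of the 4 values shown sits.

The compounds shown leave open how far past the limit compound 4 lies, and whether an amine or a methoxy group on this aromatic carbon would move the number beyond the scatter.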